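Swapping an Ester for a Hydroxymethyl Group

This account rests on a few compounds, and the source may have more. Where it says the series, first, only, none or still open, it means among the compounds named here.

Compound 1 `CCOC(=O)C1(C(=O)Nc2ccccc2)CC1c1cc(OC)c(OC)c(OC)c1` was tested in a functional assay on QGY cells (Homo sapiens) for cytotoxicity, read by MTT assay, with a stated time of 48 h (a higher number here means a weaker inhibitor, a lower number a stronger inhibitor), where it gives 59300 nM; > 100000 nM (2 entries). Part of that record is a limit of the assay, not a number. Compound 2 `CCOC(=O)[C@]1(C(=O)Nc2ccccc2)C[C@H]1c1cc(OC)c(OC)c(OC)c1` differs from compound 1 only in being drawn with a defined configuration (the fact that one of compounds 1 and 2 is drawn with a defined configuration and the other without, at the place where they differ). In this assay compound 2 gives > 100000 nM, which is a limit of the assay rather than a number, so compound 2 stands at the weak end of the values shown. Compound 3 `CCOC(=O)[C@]1(C(=O)Nc2ccccc2Cl)C[C@H]1c1cc(OC)c(OC)c(OC)c1` gives 28000 nM in this assay, and the step of an at least 3.5-fold lower number from compound 2 to compound 3 (0.55 log units; beyond the scatter) is the only measured one. Compound 4 `COc1cc([C@@H]2C[C@]2(CO)C(=O)Nc2ccccc2)cc(OC)c1OC` differs from compound 2 by hydroxymethyl in place of ethoxycarbonyl on a saturated ring carbon. Among the compounds with values here, no measured step touches the ethoxycarbonyl group, so no step beyond the scatter is expected. The expected step is a number no higher from compound 2 to compound 4 (the limit leaves the size open). Compound 4 is therefore estimated at 100000 nM, between 30000 nM and 300000 nM.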

Compound 4, half-maximal inhibitory concentration: 51300 nM
Compound 4: the middle estimate sits 1.9-fold (0.29 log units) above what was measured; low and high end bracket the measured number.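

Within the data shown here, this is the first measured change at the saturated ring carbon bearing the ethoxycarbonyl group, and in this assay it reads as an at least 1.9-fold lower number from compound 2 to compound 4 (0.28 log units; that floor lies within the scatter). Compound 2 stands at a limit of the assay, > 100000 nM. Going by these compounds, the true size of the step therefore stays open, but compound 4 shows that a number can still be measured with hydroxymethyl in place of ethoxycarbonyl.

On these data alone, how an amine or a carboxylic acid on this ring carbon would read stays open. So does whether chloro on the aromatic ring would lower the number for compound 4 as well.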